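Nitro compound at the assay limit: losing a methyl

The compounds below may be only part of what the source reports. "The series", "measured", "known", "first", "only" and "open" are said of these compounds alone.

Measured compounds in a functional assay on A10 cells (Rattus norvegicus) for activation, read by immunofluorescence, with a stated time of 18 h; a higher number here means that more compound is needed for the effect, a lower number that less compound is needed:
Compound 1 `CNc1ccc(N(C)c2ncnc3occ(C)c23)cc1`: 240 nM
Compound 2 `Cc1coc2ncnc(N(C)c3ccc(N(C)C)cc3)c12`: 140 nM
Compound 3 `Cc1coc2ncnc(N(C)c3ccc([N+](=O)[O-])cc3)c12`: > 10000 nM (a limit, not a number)

Compound 3 is known only through (the limit of > 10000 nM in this assay, at which 1 of the 3 values shown sits), so it has no number of its own.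

Compound 4 `Cc1coc2ncnc(Nc3ccc([N+](=O)[O-])cc3)c12` departs from compound 3 by hydrogen in place of methyl on a nitrogen on an aromatic ring. The nearest measured change of this kind is a 1.7-fold lower number from compound 1 to compound 2 (0.23 log units; within the scatter). That swap runs the other way and sits on another nitrogen of the molecule, so it is only a loose guide. The large steps are an at least 41-fold higher number from compound 1 to compound 3 (1.61 log units; beyond the scatter) and an at least 71-fold higher number from compound 2 to compound 3 (1.85 log units; beyond the scatter), and both end at the nitro compound. Within the data shown here, compound 4 keeps the nitro group, and no measured pair shows the methyl being removed from the nitrogen it leaves here. A recovery on the scale of those large steps is therefore not expected from this small change, and a second reading at the limit in this assay is the likeliest outcome.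

The expected step is a step that the limit leaves unreadable from compound 3 to compound 4, which is estimated to show no clear move away from the limit. The estimate for compound 4 is 15000 nM, with an expected range from 5000 nM to 40000 nM.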

Compound 4, half-maximal effective concentration: > 10000 nM
Compound 4: a limit, no number; the forecaster's own chance of this, stated with the estimate: 80%; the middle value lies beyond the limit too.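

In this assay, compound 3 and compound 4 both stand at a limit and not at a number, so no step between them can be read: the limit of > 10000 nM in this assay, at which 2 of the 4 values shown sit.

The compounds shown leave open whether hydrogen in place of methyl on this nitrogen changes the response at all while the nitro group stays, since neither nitro compound has a number of its own.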